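Methyl on the fused ring of compound 2: an expectation

The source may hold more compounds than are shown below. What is called first, only, known or untested is meant among the compounds shown, and "the series" means these compounds.

The measured compounds are:
compound 1, `Cc1nc(C)n(CC(=O)N2CCN(c3sc(C(F)(F)F)nc3-c3nc4c(F)cccc4[nH]3)C[C@H]2C)n1`, which in a functional assay on CHO-K1 cells for antagonist activity at C-X-C chemokine receptor type 3 (Homo sapiens), read by FLIPR, with a stated time of 10 min, in the presence of a further agent that is not named here (on this read-out higher numbers stand for weaker inhibition and lower numbers for stronger inhibition), gives 3.1 nM;
compound 2, `Cc1nc(C)n(CC(=O)N2CCN(c3sc(C(F)(F)F)nc3-c3nc4ccccc4[nH]3)C[C@H]2C)n1`, which in this assay gives 3.2 nM;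
compound 3, `C[C@@H]1CN(c2sc(C(F)(F)F)nc2-c2nc3ccccc3[nH]2)CCN1C(=O)Cn1cnc2c1CCN(C)C2`, which in this assay gives 3.6 nM.

Compound 2 sits within the usual scatter of both neighbours: the step of a 1.0-fold higher number from compound 1 to compound 2 (0.01 log units; within the scatter) and the step of a 1.1-fold higher number from compound 2 to compound 3 (0.05 log units; within the scatter) are each too small to count as a change. The unmeasured compound 4, `Cc1nc(C)n(CC(=O)N2CCN(c3sc(C(F)(F)F)nc3-c3nc4cccc(C)c4[nH]3)C[C@H]2C)n1`, differs from compound 2 by methyl in place of hydrogen on an aromatic carbon. For the measured compounds named here, only the step from compound 1 to compound 2 bears directly on this change, since it too alters a substituent on the six-membered carbon ring of the fused system, and it was a 1.0-fold higher number from compound 1 to compound 2 (0.01 log units; within the scatter). The step from compound 2 to compound 3 concerns a different part of the molecule and says nothing here. A small group on the fused ring has therefore left this assay untouched once, and no step beyond the scatter is expected now. Compound 4 is estimated at 4 nM, between 1.5 nM and 11 nM, an expected step of a 1.3-fold higher number from compound 2 to compound 4 (0.10 log units; within the scatter).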

Compound 4, half-maximal inhibitory concentration: 3.1 nM
The estimate for compound 4 lay 1.3-fold (0.11 log units) above the measured number; the measured number falls inside the stated range.
By their numbers in this assay, from the lowest: compounds 1, 4, 2 and 3 (each within the scatter of the next).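

Methyl in place of hydrogen on the six-membered aromatic ring of carbon only gives a 1.0-fold lower number from compound 2 to compound 4 (0.01 log units; within the scatter) in this assay, so a carbon substituent joins the fluoro of compound 1 as a second small group on this ring that leaves the read-out within the scatter. The direct exchange of 4-fluoro-1H-benzimidazol-2-yl for 7-methyl-1H-benzimidazol-2-yl gives no change at the digits printed from compound 1 to compound 4 (within the scatter) in the same assay, so the two groups cannot be told apart here. This holds for these compounds only.

Going by these compounds, whether an aminomethyl group, a carboxylic acid or a longer chain such as propyl on this ring would leave the read-out equally flat remains open. Nothing at hand explains why methyl and fluoro read alike in this assay.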